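Working notes on the step to compound 4

This account rests on a few compounds, and the source may have more. Where it says the series, first, only, none or still open, it means among the compounds named here.

- Compound 1 `O=C(c1ccc(F)cc1)c1ccn(-c2ccc3c(c2)B(O)OC3)c1` gives > 10 ug/mL as a limit
- Compound 2 `O=C(CCc1ccccc1)c1ccn(-c2ccc3c(c2)B(O)OC3)c1` gives > 10 ug/mL as a limit
- Compound 3 `Cc1ccc(C(=O)c2ccn(-c3ccc4c(c3)B(O)OC4)c2)s1` gives > 10 ug/mL as a limit

In an ADME assay on L929 cells (Mus musculus) for cytotoxicity, read by resazurin assay, with a stated time of 72 h (on this read-out higher numbers stand for weaker inhibition and lower numbers for stronger inhibition), compound 3 reads > 10 ug/mL as a limit and not a number. All three measured compounds sit at one limit (the limit of > 10 ug/mL in this assay, at which 3 of the 3 values shown sit). Compound 4 `Cc1ccsc1C(=O)c1ccn(-c2ccc3c(c2)B(O)OC3)c1` has the same atoms as compound 3, joined differently (3-methylthiophen-2-yl in place of 5-methylthiophen-2-yl on a carbonyl carbon). The measured steps at that carbonyl carbon are a step that the two limits leave unreadable from compound 1 to compound 3 and a step that the two limits leave unreadable from compound 2 to compound 3 and a step that the two limits leave unreadable from compound 1 to compound 2 and none of them gives a size. No step beyond the scatter is therefore expected in this assay and no direction can be assigned. The expected step stands as a step that the limit leaves unreadable from compound 3 to compound 4 on this reading. The estimated value for compound 4 is 15 ug/mL (expected range 6 ug/mL to 40 ug/mL).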

Compound 4, half-maximal inhibitory concentration: > 10 ug/mL
Compound 4 was reported as a limit (the forecaster's own chance of this, stated with the estimate: 85%); the middle value is on the limit's open side.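

Compound 4 reads > 10 ug/mL in this assay, a limit and not a number. No step among compound 1, compound 2, compound 3 and compound 4 can be read: the limit of > 10 ug/mL in this assay, at which 4 of the 4 values shown sit.

The compounds shown leave open where their actual values lie in this assay, and whether the group on the carbonyl carbon matters there at all.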